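(Methoxycarbonyl)methyl in Place of Cyclohexyl

A few compounds are considered here, and "the series" means these few. Any claim that something is new, unique, unknown or untested is made for them only; others in the source may bear on it.

In a functional assay on RS4-11 cells (Homo sapiens) for antiproliferative activity, read by MTT assay, with a stated time of 48 h (a lower number here means that less compound is needed, a higher number that more compound is needed for the effect), compound 1 `COC(=O)c1[nH]c2cc(OC)ccc2c1-c1ccc(Br)cc1` with a 4-bromophenyl group on an aromatic carbon of the shared core gives 200 nM as a measured number. Compound 2 `COC(=O)c1[nH]c2cc(OC)ccc2c1C` with methyl in that place gives > 100000 nM which is a limit and not a number. Compound 3 `COC(=O)c1[nH]c2cc(OC)ccc2c1C1CCCCC1` with cyclohexyl there gives > 100000 nM which is likewise a limit, so it has no measured number to start from.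

Compound 4 `COC(=O)Cc1c(C(=O)OC)[nH]c2cc(OC)ccc12` brings the next change in (methoxycarbonyl)methyl in place of cyclohexyl on an aromatic carbon with (methoxycarbonyl)methyl in place of cyclohexyl on an aromatic carbon. For the measured compounds named here, two measured steps bear most on this change: an at least 500-fold higher number from compound 1 to compound 2 (2.69 log units; beyond the scatter) and an at least 500-fold higher number from compound 1 to compound 3 (2.69 log units; beyond the scatter) are both large, and compound 4 lacks the 4-bromophenyl group as well. The remaining step that the two limits leave unreadable from compound 2 to compound 3 adds nothing further. Going by the values given here, only compound 1 gives a number so far, so no large gain is expected from the new group. The expected outcome is an at least 1.2-fold lower number from compound 3 to compound 4 (0.09 log units; that floor lies within the scatter) on this estimate, which would mean no readable change. For compound 4 the estimate is 80000 nM with an expected range from 20000 nM to 200000 nM in this assay and a limit remains the likeliest report.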

Compound 4, half-maximal effective concentration: > 100000 nM
Compound 4 gave a limit, no number; the forecaster's own chance of this, stated with the estimate: 75%; middle value at least 1.2-fold (0.09 log units) from the limit.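

Setting (methoxycarbonyl)methyl in place of 4-bromophenyl gives an at least 500-fold higher number from compound 1 to compound 4 (2.69 log units; beyond the scatter) in this assay, which makes it the third replacement at this position to show such a large step from compound 1. Compound 4 gives > 100000 nM as a limit and not a number, and the steps among compound 2, compound 3 and compound 4 cannot be read, so nothing can be said about how these three groups rank against each other. Methyl and cyclohexyl hold carbon only, while (methoxycarbonyl)methyl brings oxygen and two hydrogen-bond acceptors on a chain without a ring, and even this different kind of group ends at the same limit: the limit of > 100000 nM in this assay, at which 3 of the 4 values shown sit.

Of the four compounds, only compound 1 gives a number, and it alone carries an aromatic ring at this position, so the part played by the ring cannot be told apart from that of its bromine. Going by these compounds, how a plain phenyl, a 4-chlorophenyl or a chain ending in an amine or a carboxylic acid would behave at this position stays open.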